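Adding an ethyl group to a compound at the assay limit

The source may report more compounds than this note shows. Statements on the series, on what has been measured and on what is new or still open speak of the compounds shown alone.

Compound 1 `S=C(N/N=C/c1cccs1)Nc1ccccc1` gives > 100000 nM
Compound 2 `S=C(N/N=C/c1cccs1)Nc1cccc2ccccc12` gives > 100000 nM

Both values come from a functional assay on UACC-62 cells (Homo sapiens) for inhibition, read by sulforhodamine B assay, with a stated time of 48 h; on this read-out lower numbers stand for stronger inhibition of growth and higher numbers for weaker inhibition of growth. For compound 1 the entry > 100000 nM is a limit of the assay and not a number. For compound 2 the entry > 100000 nM is likewise a limit. Compound 1 therefore stands at the limit of > 100000 nM in this assay, at which 2 of the 2 values shown sit, with no measured number to anchor it.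

Compound 3 `CCc1ccc(NC(=S)N/N=C/c2cccs2)cc1` has not yet been measured. It keeps the core of compound 1 and differs by ethyl in place of hydrogen on an aromatic carbon, para to a large group. Within the data shown here, no measured step shows what such a change does in this assay. A small move toward stronger inhibition of growth is expected, possibly none beyond the scatter, and the estimated step is an at least 1.4-fold lower number from compound 1 to compound 3 (0.15 log units; that floor lies within the scatter). For compound 3 the estimated value is 70000 nM, with an expected range from 20000 nM to 200000 nM.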

Compound 3, concentration for 50% growth inhibition: > 100000 nM
Compound 3 ended at the assay's limit (the forecaster's own chance of this, stated with the estimate: 50%); at least 1.4-fold (0.15 log units) between middle value and limit.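

No step can be read from compound 1 to compound 3, since the entry for each is a limit of the assay and not a number: the limit of > 100000 nM in this assay, at which 3 of the 3 values shown sit.

The compounds shown leave open what size of effect, if any, ethyl in place of hydrogen has in this assay.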